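Swapping a fused indole for a cyanophenyl at a sensitive position

The source may report more compounds than this note shows. Statements on the series, on what has been measured and on what is new or still open speak of the compounds shown alone.

Of the compounds shown here, two sharing one core have been measured in a functional assay on B16-F0 cells (Mus musculus) for inhibition, read by CCK-8 assay, with a stated time of 48 h; a lower number here means a stronger inhibitor, a higher number a weaker inhibitor. Compound 1 `COc1cc(-c2ccnc3cc(-c4ccc5cnn(C)c5c4)nn23)cc(OC)c1OC` gives 1000 nM. Among the compounds with values here, compound 2 `COc1cc(-c2ccnc3cc(-c4ccc5c(ccn5C)c4)nn23)cc(OC)c1OC` gives 48 nM, the lowest of the two numbers; the only neighbour is compound 1, reached by a 21-fold lower number from compound 1 to compound 2 (1.32 log units; beyond the scatter). Compound 3 `COc1cc(-c2ccnc3cc(-c4cccc(C#N)c4)nn23)cc(OC)c1OC` differs from compound 2 in one place: 3-cyanophenyl in place of 1-methyl-1H-indol-5-yl on an aromatic carbon. Within the data shown here, the single measured step bears on this only indirectly, but it shows that the group at this position can move the number a great deal, as the step from compound 1 to compound 2 did. Losing the fused two-ring group for a smaller single ring is expected to cost potency, so a rise by an 8.3-fold higher number from compound 2 to compound 3 (0.92 log units; beyond the scatter) is estimated, placing compound 3 between the two measured compounds or somewhat above. Compound 3 is therefore expected to give about 400 nM, within 100 nM to 2000 nM.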

Compound 3, half-maximal inhibitory concentration: > 10000 nM
Compound 3: no number, only a limit; the forecaster's own chance of this, stated with the estimate: 5%; middle value at least 25-fold (1.39 log units) away from the limit.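

Compound 3 has no number in this assay, only a limit of the assay: the limit of > 10000 nM in this assay, at which 1 of the 3 values shown sits. Compounds 1 and 2 both carry fused two-ring groups and both give measured values, so they showed only that the choice of fused group matters; the single-ring 3-cyanophenyl brings an at least 200-fold higher number from compound 2 to compound 3 (2.31 log units; beyond the scatter). It also falls behind the weaker fused group, with an at least 10-fold higher number from compound 1 to compound 3 (1.00 log units; beyond the scatter), so this position, on an aromatic carbon next to the ring nitrogen, is less forgiving than the first pair suggested.

The compounds shown cannot separate the loss of the second fused ring from the arrival of the nitrile. A plain phenyl, or a phenyl bearing a methoxy group or an amine at the same ring position, would help tell those two changes apart.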